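A few compounds are considered here, and "the series" means these few. Any claim that something is new, unique, unknown or untested is made for them only; others in the source may bear on it.

Measured compounds:
compound 1, `CCOC(=O)C(=O)Nc1cccc(OC)c1C#N`, 55.5 mg/kg
compound 2, `CCOC(=O)C(=O)Nc1cccc(NC)c1C#N`, 0.1 mg/kg
compound 3, `CCOC(=O)C(=O)Nc1cccc(OC(C)C)c1C#N`, 1 mg/kg

These three compounds share one core and differ only in the group that sits ortho to the cyano group. In a functional assay on the whole organism with Rattus norvegicus as the target (a lower number here means that less compound is needed, a higher number that more compound is needed for the effect), compound 2 gives the lowest number of the three: compound 3 stands nearest, with a 10-fold higher number from compound 2 to compound 3 (1.00 log units; beyond the scatter), and compound 1 furthest, with a 560-fold lower number from compound 1 to compound 2 (2.74 log units; beyond the scatter) going the other way. Changing the group at this position has therefore moved the read-out a great deal in every case seen so far, including a 56-fold lower number from compound 1 to compound 3 (1.74 log units; beyond the scatter).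

Compound 4, `CCOC(=O)C(=O)Nc1cccc(F)c1C#N`, has not yet been measured in this assay. It differs from compound 2 in one place: fluoro in place of methylamino on an aromatic carbon. For the measured compounds named here, no measured step covers this exact exchange, so the expectation rests only on the sizes of the changes already seen and on the fact that compound 2 holds the lowest number. The step is expected to go toward a higher number, with a 100-fold higher number from compound 2 to compound 4 (2.00 log units; beyond the scatter). Compound 4 is therefore estimated at 10 mg/kg, within a range from 1 mg/kg to 100 mg/kg.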

Compound 4, dose for half-maximal effect: 59 mg/kg
For compound 4 the middle estimate is 5.9-fold (0.77 log units) below the measured one, and the stated range covers the measured number.
By their numbers in this assay, from the lowest: compound 2; then compound 3; then compounds 1 and 4 (each within the scatter of the next).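

In this assay, replacing a larger group with fluoro gives a large rise in the dose needed, both from methylamino (a 590-fold higher number from compound 2 to compound 4 (2.77 log units; beyond the scatter)) and from isopropoxy (a 59-fold higher number from compound 3 to compound 4 (1.77 log units; beyond the scatter)). Fluoro and methoxy, by contrast, cannot be told apart (a 1.1-fold higher number from compound 1 to compound 4 (0.03 log units; within the scatter)), so among these four compounds the high end of the scale is shared by different groups, while only methylamino and isopropoxy give low numbers. Nothing available here explains why these groups differ so widely.

The compounds shown leave open whether a plain amino group, an ethylamino group or a dimethylamino group would keep the low number of compound 2 (0.1 mg/kg). They also leave open where an ethoxy group would fall, given the wide gap between methoxy and isopropoxy.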